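The compounds below may be only part of what the source reports. "The series", "measured", "known", "first", "only" and "open" are said of these compounds alone.

Of the compounds shown here, three from this series have already been measured in an assay on cell membranes for displacement of a labelled ligand from metabotropic glutamate receptor 5 (Rattus norvegicus); a higher number here means a weaker inhibitor, a lower number a stronger inhibitor. Compound 1, whose structure is `Cc1cccc(-n2nnc(C3CCCCN3C(=O)C3CCCC3)n2)c1`, gives 102 nM. Compound 2, with the structure `Cc1ccc(C(=O)N2CCCC2c2nnn(-c3cccc(Cl)c3)n2)o1`, gives 105 nM. Compound 3, drawn as `CC(C)C(=O)N1CCCCC1c1nnn(-c2cccc(Cl)c2)n1`, gives 138 nM, the highest of the three numbers, yet its gaps to compound 2 and to compound 1 both lie within the scatter, so the three compounds are not distinguishable on these figures.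

Compound 4, with the structure `O=C(c1ccco1)N1CCCCC1c1nnn(-c2cccc(Cl)c2)n1`, is not yet measured. It differs from compound 3 in one place: furan-2-yl in place of isopropyl on a carbonyl carbon. For the measured compounds named here, the two measured compounds carrying a ring on the carbonyl carbon, compound 1 and compound 2, give numbers indistinguishable from compound 3, and no step between measured compounds isolates this change. The step from compound 3 to compound 4 in this assay is therefore expected to be small, a 1.4-fold lower number from compound 3 to compound 4 (0.14 log units; within the scatter), probably not beyond the scatter, with a slight lean toward a lower number because compound 2 gives 105 nM. Compound 4 is estimated at 100 nM, with a range from 40 nM to 250 nM.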

Compound 4, inhibition constant: 126 nM
Beside the measured number, compound 4's estimate is 1.3-fold (0.10 log units) below it, within the range that was stated.
By their numbers in this assay, from the lowest: compounds 1, 2, 4 and 3 (each within the scatter of the next).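

In this assay, for the compounds shown here, furan-2-yl in place of isopropyl on a carbonyl carbon gives a 1.1-fold lower number from compound 3 to compound 4 (0.04 log units; within the scatter), and this is the first step that isolates a single change. It shows that, at this position, a group with no ring and a larger group carrying a five-membered aromatic ring and one hydrogen-bond acceptor cannot be told apart on these figures. Nothing measured here speaks to why the two groups read alike. On these data alone, what a phenyl ring, an amine or a carboxylic acid, or a longer chain would do on this carbonyl carbon remains open. Also open, as far as these compounds go, is whether the same swap would give a step of this size on a different core, such as the core of compound 2.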